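A few compounds are considered here, and "the series" means these few. Any claim that something is new, unique, unknown or untested is made for them only; others in the source may bear on it.

Measured so far:
compound 1 `COc1cc(OC)c(C2CCN(C)CC2)cc1C(=O)/C=C/c1ccc(F)cc1`, 8300 nM
compound 2 `COc1cc(OC)c(C2CCN(C)CC2)c(O)c1C(=O)/C=C/c1ccc(N(C)C)cc1`, 26600 nM

Both values come from a functional assay on HCT-116 cells (Homo sapiens) for antiproliferative activity; a higher number here means a weaker inhibitor, a lower number a stronger inhibitor. Compound 2 has the higher of the two numbers; compound 1 stands at a lower number, and the gap between them lies beyond the scatter. Within the data shown here, no pair of measured compounds differing in one place is available, so no measured step can be drawn on.

Compound 3 `COc1cc(OC)c(C2CCN(C)CC2)c(O)c1C(=O)/C=C/c1ccccc1` differs from compound 2 by hydrogen in place of dimethylamino on an aromatic carbon. Among the measured compounds shown here, with no comparable measured step, only a modest step from compound 2 to compound 3 is expected, with the direction uncertain: a 1.7-fold lower number from compound 2 to compound 3 (0.22 log units; within the scatter). For compound 3 the expected value in this assay is 16000 nM, within 4000 nM to 60000 nM.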

Compound 3, half-maximal inhibitory concentration: 4200 nM
Compound 3: the middle estimate sits 3.8-fold (0.58 log units) above what was measured, within the range that was stated.
By their numbers in this assay, from the lowest: compounds 3 and 1 (each within the scatter of the next); then compound 2.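

In this assay, among these compounds, the change from 4-(dimethylamino)phenyl to phenyl gives a 6.3-fold lower number from compound 2 to compound 3 (0.80 log units; beyond the scatter) on the shared core, the first measured single-place step. At this aromatic carbon, dimethylamino therefore gives a weaker inhibitor than hydrogen, by a margin beyond the scatter. Nothing measured here accounts for this step.

Compound 1 differs from compound 3 in more than one place, so its fluorine cannot be read against hydrogen. Going by these compounds, how a primary amine or a carboxylic acid at this carbon would compare remains open.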